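The compounds below may be only part of what the source reports. "The series", "measured", "known", "first", "only" and "open" are said of these compounds alone.

Working notes on the selenoimidate bis-amide series, followed in an ADME assay on MCF-10A cells (Homo sapiens) for cytotoxicity, read by MTT assay, with a stated time of 72 h; on this read-out lower numbers stand for stronger inhibition of growth and higher numbers for weaker inhibition of growth. Compound 1 `C[Se]/C(=N\C(=O)c1ccco1)NC(=O)c1ccco1` gives 5940 nM in this assay. Compound 2 `C[Se]/C(=N\C(=O)c1cccs1)NC(=O)c1cccs1` gives 9260 nM, and compound 3 `C[Se]/C(=N\C(=O)c1cc(-c2ccccc2)nc2ccccc12)NC(=O)c1cc(-c2ccccc2)nc2ccccc12` gives 710 nM. Among the three numbers compound 1 holds the second highest; compound 2 lies nearest, within the scatter, so no order between compound 1 and compound 2 is claimed, while compound 3 stands furthest, with a lower number beyond the scatter.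

Compound 4 `O=C(/N=C(/NC(=O)c1ccco1)[Se]Cc1ccccc1)c1ccco1` has not yet been measured in this assay. Against compound 1 the change is phenyl in place of hydrogen on a saturated chain carbon bound to a selenium atom; cut one bond further out it reads methyl to benzyl. Within the data shown here, no step between measured compounds covers such a change at the selenium-bound chain carbon, so nothing measured sizes it. Compound 3, with its value 710 nM, carries larger aromatic groups than compound 1, but at another place of the shared core, and offers only weak guidance. The step expected a 1.3-fold lower number from compound 1 to compound 4 (0.12 log units; within the scatter) is small, toward a lower number, and not clearly beyond the scatter. For compound 4 in this assay a number of 4500 nM is estimated, in the range 1500 nM to 13000 nM.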

Compound 4, concentration for 50% growth inhibition: 8800 nM
For compound 4 the middle estimate is 2.0-fold (0.29 log units) below the measured one; measured number inside the range.
By their numbers in this assay, from the lowest: compound 3; then compounds 1, 4 and 2 (each within the scatter of the next).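

Phenyl in place of hydrogen on a saturated chain carbon bound to a selenium atom now has a measured size: in this assay the step reads a 1.5-fold higher number from compound 1 to compound 4 (0.17 log units; within the scatter) and so does not separate the benzyl compound from the methyl compound. At this place, then, a six-membered aromatic ring of carbon only can be carried on the core of compound 1 with no change that can be claimed in growth inhibition, though this rests on a single pair. Nothing available explains this result.

From the compounds shown here alone, whether a longer chain such as phenethyl, an amine or a carboxylic acid at this same chain carbon would give a step beyond the scatter remains open. Also open, going by these compounds, is whether methyl to benzyl reads the same on the core of compound 2 or of compound 3.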